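The compounds below may be only part of what the source reports. "The series", "measured", "known", "first", "only" and "open" are said of these compounds alone.

Compound 1, `O=c1[nH]c(=O)n(CCC(CO)CO)cc1-c1ccco1`, gives > 100000 nM in a functional assay on SW-620 cells (Homo sapiens) for antiproliferative activity, read by MTT assay, with a stated time of 72 h; a higher number here means a weaker inhibitor, a lower number a stronger inhibitor; this is a limit of the assay, not a number.
Compound 2, `O=c1[nH]c(=O)n(CCC(CO)CO)cc1C#Cc1cc(F)cc(F)c1`, gives > 100000 nM in this assay; this too is a limit.
Compound 3, `O=c1[nH]c(=O)n(CCC(CO)CO)cc1C#CC1CC1`, gives > 100000 nM in this assay; again a limit.

All three measured members of the series therefore stand at the same point, (the limit of > 100000 nM in this assay, at which 3 of the 3 values shown sit), and none gives a number. Compound 3 is known only as a limit. The two steps that lead to it, a step that the two limits leave unreadable from compound 1 to compound 3 and a step that the two limits leave unreadable from compound 2 to compound 3, cannot be read in size or direction, since both ends are limits.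

Compound 4, `CCCCCC#Cc1cn(CCC(CO)CO)c(=O)[nH]c1=O`, is not yet measured. Its change from compound 3 is pentyl in place of cyclopropyl on a triple-bonded carbon, the cyclopropyl leaving and the pentyl entering on a triple-bonded carbon. Among the measured compounds shown here, the only steps that touch this position are the two unreadable ones above, so no direction can be read for the expected step of a number no higher from compound 3 to compound 4 (the limit leaves the size open) in this assay, which is expected to stay unreadable. With the whole series at the limit, compound 4 is estimated at 100000 nM, within a range of 30000 nM to 300000 nM, most likely reported as a limit again.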

Compound 4, half-maximal inhibitory concentration: > 100000 nM
Compound 4: only a limit was reported; the forecaster's own chance of this, stated with the estimate: 85%; the middle value lies on the limit itself.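

Compound 4 is also known only as a limit, so none of its steps from compound 1, compound 2 and compound 3 can be read in size or direction, and the series stays at a single point in this assay: the limit of > 100000 nM in this assay, at which 4 of the 4 values shown sit.

From the compounds shown here alone, whether any of these four compounds differs from another in this assay, and whether any group on the shared core gives a readable number, stays open.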